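The compounds below may be only part of what the source reports. "The series", "measured", "known", "first", "only" and "open" are said of these compounds alone.

Values so far in a functional assay on HepG2 cells (Homo sapiens) for antiproliferative activity, read by MTT assay, with a stated time of 48 h; on this read-out lower numbers stand for stronger inhibition and higher numbers for weaker inhibition:
- compound 1 `O=c1cc(-c2ccccc2)oc2cc(OCc3ccccc3)c(OCCCCN3CCCCC3)c(O)c12` gives 2400 nM
- compound 2 `COc1cc2oc(-c3ccccc3)cc(=O)c2c(O)c1OCCCN1CCCCC1` gives 22300 nM
- compound 3 `COc1cc2oc(-c3ccccc3)cc(=O)c2c(O)c1OCCCCN1CCCCC1` gives 21000 nM

Compound 3 lies in the high part of this small range. Its near neighbour is shown by the step (a 1.1-fold lower number from compound 2 to compound 3 (0.03 log units; within the scatter)) and its distant one by the step (an 8.8-fold higher number from compound 1 to compound 3 (0.94 log units; beyond the scatter)).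

Next to be read is compound 4 `CCN(CC)CCCOc1c(OC)cc2oc(-c3ccccc3)cc(=O)c2c1O`, which differs from compound 3 as follows (diethylamino in place of (piperidin-1-yl)methyl on a saturated chain carbon, three bonds along the chain from an oxygen on an aromatic ring). In words, diethylamino stands in place of (piperidin-1-yl)methyl on a saturated chain carbon, three bonds along the chain from an oxygen on an aromatic ring. Cut further out, the same difference reads 4-(piperidin-1-yl)butyl to 3-(diethylamino)propyl.

The measured step at this place (a 1.1-fold lower number from compound 2 to compound 3 (0.03 log units; within the scatter)) stays within the scatter. The other measured step (an 8.8-fold higher number from compound 1 to compound 3 (0.94 log units; beyond the scatter)) is larger, but it is a different change at a different place and says little here. Within the data shown here, no measured compound carries diethylamino, so that part of the change is untested.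

On this basis, no shift beyond the scatter is expected in this assay for this change. The expected step is small (a 1.1-fold lower number from compound 3 to compound 4 (0.02 log units; within the scatter)). For compound 4 the estimated value is 20000 nM with an expected range from 9000 nM to 45000 nM on this read-out.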

Compound 4, half-maximal inhibitory concentration: 3700 nM
The estimate for compound 4 lay 5.4-fold (0.73 log units) above the measured number; measured number outside the range, below it.
By their numbers in this assay, from the lowest: compounds 1 and 4 (each within the scatter of the next); then compounds 3 and 2 (each within the scatter of the next).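

In this assay, the amine at the end of the chain proves to be a sensitive feature: with the chain kept the same, diethylamino in place of piperidin-1-yl gives a clear shift (a 6.0-fold lower number from compound 2 to compound 4 (0.78 log units; beyond the scatter)), and the step measured against the 4-(piperidin-1-yl)butyl chain is of similar size (a 5.7-fold lower number from compound 3 to compound 4 (0.75 log units; beyond the scatter)). Until now this place had shown only a step within the scatter (a 1.1-fold lower number from compound 2 to compound 3 (0.03 log units; within the scatter)), so the change of the ring-bearing amine to an open-chain one shows a response that lengthening the chain with piperidin-1-yl kept did not. No measurement at hand accounts for this shift.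

Dimethylamino, pyrrolidin-1-yl and morpholin-4-yl on the same chain would show whether the shift holds for open-chain amines in general or belongs to diethylamino alone. A 4-(diethylamino)butyl chain would show whether chain length stays without effect with this amine, and a benzyl ether in place of the methyl ether of compound 4 would show whether the two changes add up.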